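The compounds below may be only part of what the source reports. "The series", "measured", "known", "first", "only" and "open" are said of these compounds alone.

Measured in a functional assay on MOLT-4 cells (Homo sapiens); a lower number here means a stronger inhibitor, a higher number a weaker inhibitor:
- Compound 1 `COc1cc(NC(C)CCCNC(=O)NCCCCCO)c2ncccc2c1`: 61000 nM
- Compound 2 `COc1cc(NC(C)CCCNC(=O)N(CCO)CCO)c2ncccc2c1`: > 100000 nM (a limit of the assay, not a number)
- Compound 3 `COc1cc(NC(C)CCCNC(=O)NCCNC(=O)NCCCC(C)Nc2cc(OC)cc3cccnc23)c2ncccc2c1`: 10000 nM

Of the two exact numbers, compound 1 at 61000 nM is the higher, and compound 3 at 10000 nM is the lower.

Compound 4 `COc1cc(NC(C)CCCNC(=O)NO)c2ncccc2c1` keeps the core of compound 1 but carries hydroxy in place of 5-hydroxypentyl on an amide-type nitrogen. For the measured compounds named here, the one measured step that also replaces this group is an at least 1.6-fold higher number from compound 1 to compound 2 (0.21 log units; that floor lies within the scatter). It rests on a limit, so it gives only a floor and no firm size.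

No step beyond the scatter is therefore expected in this assay, and the expected change is a 1.5-fold lower number from compound 1 to compound 4 (0.18 log units; within the scatter). For compound 4 the estimate is 40000 nM, with an expected range of 12000 nM to 100000 nM.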

Compound 4, half-maximal inhibitory concentration: > 100000 nM
Compound 4: no number, only a limit; the forecaster's own chance of this, stated with the estimate: 15%; middle value at least 2.5-fold (0.39 log units) from the limit.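

In this assay compound 4 gives > 100000 nM, which is a limit of the assay and not a number. Replacing 5-hydroxypentyl with hydroxy on the amide-type nitrogen yields only a floor, an at least 1.6-fold higher number from compound 1 to compound 4 (0.21 log units; that floor lies within the scatter), so this much shorter group brings no gain in strength. The step between compound 2 and compound 4 cannot be read, and neither can be ranked against the other: the limit of > 100000 nM in this assay, at which 2 of the 4 values shown sit.

From the compounds shown here alone, how far either compound lies past that limit stays open. So does whether an amine, a carboxylic acid or a longer chain on this nitrogen would give a lower number than compound 1.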